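Swapping a methoxymethyl for a cyclobutyl on an aryl ether

This account rests on a few compounds, and the source may have more. Where it says the series, first, only, none or still open, it means among the compounds named here.

Measured compounds:
compound 1 `Cc1nc(O)c2cc(-c3ccc(Cl)c(OCC(=O)O)c3)c(C(C)C)cc2n1`: > 1000 nM
compound 2 `COCCOc1cc(-c2cc3c(O)nc(C)nc3cc2C(C)C)ccc1Cl`: 216 nM

Going by the values given here, compound 2 `COCCOc1cc(-c2cc3c(O)nc(C)nc3cc2C(C)C)ccc1Cl` holds the only number in a functional assay for inhibition of transient receptor potential cation channel subfamily V member 1 (Homo sapiens), read by fluorescence and calcium flux; on this read-out lower numbers stand for stronger inhibition and higher numbers for weaker inhibition; compound 1 `Cc1nc(O)c2cc(-c3ccc(Cl)c(OCC(=O)O)c3)c(C(C)C)cc2n1` reaches only the limit (the limit of > 1000 nM in this assay, at which 1 of the 2 values shown sits). Compound 3 `Cc1nc(O)c2cc(-c3ccc(Cl)c(OCC4CCC4)c3)c(C(C)C)cc2n1` differs from compound 2 in one place: cyclobutyl in place of methoxymethyl on a saturated chain carbon bound to an oxygen on an aromatic ring. Among the compounds with values here, the one measured step, an at least 4.6-fold lower number from compound 1 to compound 2 (0.66 log units; beyond the scatter), removed the carboxy and does not involve the cyclobutyl, so it offers no direct guide; no step beyond the scatter is expected. In this assay compound 3 is estimated at 170 nM, between 55 nM and 600 nM, a step of a 1.3-fold lower number from compound 2 to compound 3 (0.10 log units; within the scatter).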

Compound 3, half-maximal inhibitory concentration: 144 nM
Beside the measured number, compound 3's estimate is 1.2-fold (0.07 log units) above it; the measured number falls inside the stated range.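

At a saturated chain carbon bound to an oxygen on an aromatic ring, the swap gives a 1.5-fold lower number from compound 2 to compound 3 (0.18 log units; within the scatter) in this assay and so shows that cyclobutyl, with 0 hydrogen-bond acceptors, can stand in for methoxymethyl, with 1, without a change beyond the scatter. Replacing the carboxy with cyclobutyl gives an at least 6.9-fold lower number from compound 1 to compound 3 (0.84 log units; beyond the scatter) and so extends what the methoxymethyl step showed to a second group. The value of compound 1 is a limit, not a number: the limit of > 1000 nM in this assay, at which 1 of the 3 values shown sits.

The compounds shown leave open how an amine or a longer chain at this place would read.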